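Replacing chloro with hydroxy on the pyrimidine of compound 3

A few compounds are considered here, and "the series" means these few. Any claim that something is new, unique, unknown or untested is made for them only; others in the source may bear on it.

Compound 1 `COc1cc(Cl)nc2n/c(=N/C(=O)c3c(-c4ccc(Cl)cc4Cl)noc3C)sn12`: 16.5%
Compound 2 `COc1cc(C)nc2n/c(=N/C(=O)c3c(-c4ccc(Cl)cc4Cl)noc3C)sn12`: 50.3%
Compound 3 `Cc1cc(Cl)nc(NC(=S)NC(=O)c2c(-c3ccc(Cl)cc3Cl)noc2C)n1`: 10.2%

In a functional assay on the whole organism for inhibition, with Digitaria ciliaris as the target, with a stated time of 72 h, tested at 10 mg/L (a lower number here means less inhibition of growth, a higher number more inhibition of growth at the concentration tested), compound 3 shows the lowest of the three numbers, with compound 1 nearest and within the scatter, and compound 2 far higher. Compound 4 `Cc1cc(O)nc(NC(=S)NC(=O)c2c(-c3ccc(Cl)cc3Cl)noc2C)n1` differs from compound 3 by hydroxy in place of chloro on an aromatic carbon. Among the measured compounds shown here, the only measured step, a number 33.8 percentage points higher from compound 1 to compound 2 (beyond the scatter), also removes a chloro from the aromatic carbon of the shared core, though on a different core and for a different entering group, so it bears on this change only loosely. Its size suggests that exchanging the chloro can move this assay a good deal, so compound 4 is expected to rise by a number 11.8 percentage points higher from compound 3 to compound 4 (beyond the scatter), with wide uncertainty. The estimate for compound 4 is 22%, between 5% and 45%.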

Compound 4, percent growth inhibition at one concentration: -6.24%
The estimate for compound 4 lay 28.2 percentage points above the measured number; measured number outside the range, below it.
By their numbers in this assay, from the lowest: compound 4; then compounds 3 and 1 (each within the scatter of the next); then compound 2.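

With this assay as the read-out, hydroxy in place of chloro on the carbon next to the ring nitrogen gives a number 16.4 percentage points lower from compound 3 to compound 4 (beyond the scatter). This shows that the position responds to the group placed there, and that this exchange lowers the number, whereas the methyl exchange on the other core gave a number 33.8 percentage points higher from compound 1 to compound 2 (beyond the scatter). Nothing measured here explains the drop.

Going by these compounds, whether an amine or an ethyl group at this position would raise the number remains open. So does whether hydroxy would lower it on the core of compound 1.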